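Thiophenylmethyl amide series: five-membered ring swap on nitrogen

The compounds below may be only part of what the source reports. "The series", "measured", "known", "first", "only" and "open" are said of these compounds alone.

Measured so far:
compound 1 `CCN(Cc1cccs1)C(=O)COc1ccc(C(=O)O)cc1` — "not active" (no number reported)
compound 2 `Cc1ccc(OCC(=O)N(Cc2cccs2)c2ccnn2C)cc1` — 422 nM
compound 3 `CCN(Cc1cccs1)C(=O)C[C@H](O)c1ccccc1` — 52000 nM

In an assay on HEK293 cells for agonist activity at transient receptor potential cation channel subfamily M member 8 (Homo sapiens), read by fluorescence and calcium flux, with a stated time of 15 min (a lower number here means that less compound is needed, a higher number that more compound is needed for the effect), compound 2 gives 422 nM, the lowest of the two numbers in hand. Compound 3 stands far higher at 52000 nM, a gap well beyond the usual scatter. Compound 1 is reported as "not active" (no number reported), without a number.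

Compound 4 `Cc1ccc(OCC(=O)N(Cc2cccs2)c2ccon2)cc1` has not been measured in this assay. It differs from compound 2 in one place: 1,2-oxazol-3-yl in place of 1-methyl-1H-pyrazol-5-yl on an amide-type nitrogen. Both groups are five-membered aromatic rings with two hetero atoms and two hydrogen-bond acceptors, so the change is modest in what is counted. With only compound 2 as the reference for this part of the molecule, the step is expected to be small, plausibly within the scatter, with a slight lean toward a higher number given the loss of one heavy atom. The estimated step from compound 2 to compound 4 is a 1.5-fold higher number from compound 2 to compound 4 (0.19 log units; within the scatter). Compound 4 is expected to give about 650 nM in this assay, within the range 150 nM to 2800 nM.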

Compound 4, half-maximal effective concentration: 2 nM
For compound 4 the middle estimate is 330-fold (2.51 log units) above the measured one; the whole stated range lies above it.
By their numbers in this assay, from the lowest: compound 4; then compound 2; then compound 3.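

In this assay the group on the amide-type nitrogen emerges as a highly sensitive position: 1,2-oxazol-3-yl in place of 1-methyl-1H-pyrazol-5-yl gives a 210-fold lower number from compound 2 to compound 4 (2.32 log units; beyond the scatter) as a large step beyond the scatter. The two groups match in ring size, hetero atom count, hydrogen-bond donors, hydrogen-bond acceptors and net charge, so these shared counts do not separate them, although the step shows that the two rings are far from interchangeable here. No measurement in hand explains the size of this step.

Whether the step follows the ring oxygen, the missing methyl or the ring's point of attachment stays open, as no methyl-substituted 1,2-oxazole or unsubstituted pyrazole is among the compounds shown. Also open, going by these compounds, is how a phenyl or pyridine ring on the same nitrogen would compare with 1,2-oxazol-3-yl.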